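The source may report more compounds than this note shows. Statements on the series, on what has been measured and on what is new or still open speak of the compounds shown alone.

Measured so far in a functional assay on HCT-15 cells (Homo sapiens) for cytotoxicity, read by sulforhodamine B assay, with a stated time of 48 h; on this read-out higher numbers stand for weaker inhibition of growth and lower numbers for stronger inhibition of growth:

compound 1, `Nc1nc(Cl)c2ncn(Cc3ccc(CCl)cc3)c2n1`: 4900 nM
compound 2, `ClCc1cccc(Cn2cnc3c(Cl)nc(Cl)nc32)c1`: 2390 nM
compound 3, `ClCc1ccc(Cn2cnc3c(Cl)nc(Cl)nc32)cc1`: 1860 nM

Compound 2 and compound 3 are built from the same atoms joined differently; the difference between the two cores is not broken down here. In this assay compound 2 and compound 3 give numbers that lie within the scatter of one another, so no order between them is claimed. Compound 1 is compound 3 with a single change, (amino in place of chloro on an aromatic carbon), and that step gave a 2.6-fold higher number from compound 3 to compound 1 (0.42 log units; beyond the scatter).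

Compound 4, `Nc1nc(Cl)c2ncn(Cc3cccc(CCl)c3)c2n1`, has not yet been measured. It stands to compound 2 as compound 1 stands to compound 3: amino in place of chloro on an aromatic carbon. The two place descriptions agree word for word, so this is the same change, made once on the core of compound 3 and once on the core of compound 2; it occurs twice in all among the compounds here.

Among the measured compounds shown here, only one measured instance of the change exists, so the expectation for compound 4 rests on it alone: the step of a 2.6-fold higher number from compound 3 to compound 1 (0.42 log units; beyond the scatter), carried over to compound 2 starting from 2390 nM. The step from compound 2 to compound 4 is expected to be a 2.6-fold higher number from compound 2 to compound 4 (0.41 log units; beyond the scatter), with wide uncertainty since a single example carries it. Compound 4 is therefore estimated at 6200 nM in this assay. For compound 4 the expected range is 3000 nM to 13000 nM.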

Compound 4, concentration for 50% growth inhibition: 2510 nM
For compound 4 the middle estimate is 2.5-fold (0.39 log units) above the measured one; measured number outside the range, below it.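

In this assay the swap of amino for chloro on the aromatic carbon between two ring nitrogen atoms gave a 1.1-fold higher number from compound 2 to compound 4 (0.02 log units; within the scatter), so on the core of compound 2 the change leaves no readable shift in growth inhibition. Set beside the only other instance, on the core of compound 3, the two steps cannot be told apart: the same change on two cores in this assay, a 2.6-fold higher number (0.42 log units; beyond the scatter) from compound 3 to compound 1 and a 1.1-fold higher number (0.02 log units; within the scatter) from compound 2 to compound 4, 2.5-fold (0.40 log units) apart, within the scatter of two such steps The pair therefore gives no ground for saying that the effect of the change depends on the core, yet it also gives no ground for treating the step seen on one core as a fixed amount to be carried to the other, since one step stands beyond the scatter, the other stands within it, and two instances are too few to settle the matter.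

The compounds shown hold only chloro and amino at this aromatic carbon, so it remains open how a methoxy group, a methylamino group or a dimethylamino group in that place would read in this assay. Also open, from the compounds shown here alone, is whether the same swap behaves alike when the chloromethyl group gives way to a hydroxymethyl group or a longer chain such as chloroethyl.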